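Pyridine for thiophene in a hydroxyphenyl cytotoxicity series

The compounds below may be only part of what the source reports. "The series", "measured", "known", "first", "only" and "open" are said of these compounds alone.

Compound 2 `Oc1cccc(-c2cc(-c3ccc(Cl)cc3)nc(-c3cccs3)c2)c1` was assessed in an ADME assay on HEK293 cells (Homo sapiens) for cytotoxicity, read by CCK-8 assay and cell counting, with a stated time of 2 days (a lower number here means a stronger inhibitor, a higher number a weaker inhibitor), where compound 2 gives 11800 nM, the highest of the two numbers recorded. Compound 3 `Oc1ccc(-c2cc(-c3ccc(Cl)cc3)nc(-c3cccs3)c2)cc1` gives 4520 nM in this assay; the step of a 2.6-fold lower number from compound 2 to compound 3 (0.42 log units; beyond the scatter) placed 4-hydroxyphenyl where 3-hydroxyphenyl had been. Compound 1 `Oc1cccc(-c2cc(-c3cccnc3)nc(-c3cccc(Cl)c3)c2)c1` also carries a pyridin-3-yl group, but in this assay compound 1 gives "not determined" (no result reported), so no number exists for it. Compound 4 `Oc1cccc(-c2cc(-c3ccc(Cl)cc3)nc(-c3cccnc3)c2)c1` differs from compound 2 by pyridin-3-yl in place of thiophen-2-yl on an aromatic carbon. Among the compounds with values here, no measured step bears on this exchange; the single measured step concerned only the hydroxyl position. With nothing pointing either way, compound 4 is expected to show a step of no change at the digits printed from compound 2 to compound 4 (within the scatter), not beyond the scatter. Compound 4 is therefore estimated at 11800 nM, with a range from 5000 nM to 28000 nM.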

Compound 4, half-maximal inhibitory concentration: 39500 nM
Estimate against measurement, compound 4: 3.3-fold (0.52 log units) below; measured number outside the range, above it.
By their numbers in this assay, from the lowest: compound 3; then compound 2; then compound 4.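

The position that carries thiophen-2-yl also bears on the number in this assay and not only the hydroxyl position, as the exchange for pyridin-3-yl gives a 3.3-fold higher number from compound 2 to compound 4 (0.52 log units; beyond the scatter) in this series. With this step, the change at this position moves the number upward, and compound 4 holds the highest number of those recorded. Nothing measured here accounts for the step. The compounds shown leave open whether this exchange would move the number in the same way with 4-hydroxyphenyl in place of 3-hydroxyphenyl. They also leave open where a plain phenyl ring or an amine at this position would fall.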